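The compounds below may be only part of what the source reports. "The series", "measured", "known", "first", "only" and "open" are said of these compounds alone.

Compound 2 `Cc1ccc(CSc2cc(Cl)c(C)cc2S(=O)(=O)/N=C(\N)n2nccc2-c2ccccc2)cc1` belongs to a small series built on a shared core, and in an ADME assay on HaCaT cells (Homo sapiens) for cytotoxicity, read by MTT assay, with a stated time of 72 h (a lower number here means a stronger inhibitor, a higher number a weaker inhibitor), compound 2 gives 20000 nM. Within the data shown here, that is the higher of the two numbers measured so far; the nearest neighbour is compound 1 `Cc1cccc(CSc2cc(Cl)c(C)cc2S(=O)(=O)/N=C(\N)n2nccc2-c2ccccc2)c1`, which in this assay gives 10000 nM, and the step of a 2.0-fold higher number from compound 1 to compound 2 (0.30 log units; within the scatter) separates them. Compound 3 `Cc1cc(S(=O)(=O)/N=C(\N)n2nccc2-c2ccccc2)c(SCc2ccccc2C(F)(F)F)cc1Cl` has not yet been measured. It differs from compound 2 in one place: 2-(trifluoromethyl)phenyl in place of 4-methylphenyl on a saturated chain carbon bound to a sulfur. Among the measured compounds shown here, the only measured step that bears on a change at this place is a 2.0-fold higher number from compound 1 to compound 2 (0.30 log units; within the scatter), which moved a methyl group around the same ring and stayed within the scatter. A trifluoromethyl group replacing the methyl has no precedent among these compounds, so the expected step of a 1.3-fold lower number from compound 2 to compound 3 (0.12 log units; within the scatter) for compound 3 is none beyond the scatter. Compound 3 is therefore estimated at 15000 nM, with a range from 5000 nM to 45000 nM.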

Compound 3, half-maximal inhibitory concentration: 20000 nM
Compound 3: middle estimate off by 1.3-fold (0.12 log units), on the low side; the measured number falls inside the stated range.
By their numbers in this assay, from the lowest: compounds 1, 2 and 3 (each within the scatter of the next).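

Measured against both earlier compounds in this assay, the new group gives no change at the digits printed from compound 2 to compound 3 (within the scatter) and a 2.0-fold higher number from compound 1 to compound 3 (0.30 log units; within the scatter) at this place. Among these compounds, until now, the only change seen on the saturated chain carbon bound to a sulfur was a methyl group moved around the same ring; compound 3 shows that a larger swap, to 2-(trifluoromethyl)phenyl with its fluorine atoms, also stays within the scatter, so all three groups tried here read alike in this cell test. Nothing available explains why the numbers stay this close.

As far as these compounds go, what remains open is whether any group at this place can give a step beyond the scatter. An amine or a carboxylic acid on the ring, or a longer chain carrying that ring, would test this.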